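The source may hold more compounds than are shown below. What is called first, only, known or untested is meant among the compounds shown, and "the series" means these compounds.

Compound 1, with the structure `N#CC1=C(N)Oc2c(c3nc4ccccc4nc3c3ccccc23)C12C(=O)N(Cc1cnnn1-c1ccc(F)cc1)c1ccccc12`, gives in an ADME assay on L02 cells (Homo sapiens) for antiproliferative activity, read by MTT assay, with a stated time of 48 h (a higher number here means a weaker inhibitor, a lower number a stronger inhibitor), a reading of > 50000 nM, which is a limit of the assay and not a number.

Compound 2, with the structure `N#CC1=C(N)Oc2c(c3nc4ccccc4nc3c3ccccc23)C12C(=O)N(Cc1cnnn1-c1ccccc1Br)c1ccccc12`, gives in this assay a reading of > 50000 nM, likewise a limit and not a number.

Both readings sit at the limit of > 50000 nM in this assay, at which 2 of the 2 values shown sit, so compound 2 stands at the same limit as compound 1, and the step that the two limits leave unreadable from compound 1 to compound 2 cannot be read in size.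

Compound 3, with the structure `CCOc1ccccc1-n1nncc1CN1C(=O)C2(C(C#N)=C(N)Oc3c2c2nc4ccccc4nc2c2ccccc32)c2ccccc21`, differs from compound 2 by ethoxy in place of bromo on an aromatic carbon. Within the data shown here, the only measured step, from compound 1 to compound 2, bears on this change solely in that a change of the group on the aromatic nitrogen left both compounds at the limit. Among the measured compounds shown here, no step in this assay is therefore expected to be readable, and the step that the limit leaves unreadable from compound 2 to compound 3 is an estimate resting on that alone. Compound 3 is expected to come out near 70000 nM, within a range of 20000 nM to 250000 nM, most likely again reported as a limit.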

Compound 3, half-maximal inhibitory concentration: > 50000 nM
Compound 3 ended at the assay's limit; the forecaster's own chance of this, stated with the estimate: 80%; the middle value lies beyond the limit too.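

The steps among compound 1, compound 2 and compound 3 cannot be read in size, since all three readings are limits and not numbers: the limit of > 50000 nM in this assay, at which 3 of the 3 values shown sit.

The compounds shown leave open what number each compound would give in this assay, and whether any group on this aromatic ring would give a reading inside the assay's range.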